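Benzyl swap, 4-methyl to 2-fluoro, in a cytotoxic series

The source may hold more compounds than are shown below. What is called first, only, known or untested is meant among the compounds shown, and "the series" means these compounds.

Measured in a functional assay on HeLa cells (Homo sapiens) for cytotoxicity, read by MTT assay, with a stated time of 48 h; on this read-out higher numbers stand for weaker inhibition and lower numbers for stronger inhibition: compound 1 `Cc1ccc(Cn2c(/C=C3\SC(=S)N(CC(=O)O)C3=O)nc3cc(F)ccc32)cc1` at 2380 nM and compound 2 `Cc1ccc(Cn2c(/C=C3\SC(=S)NC3=O)nc3ccccc32)cc1` at 25300 nM. Compound 3 `O=C(O)CN1C(=O)/C(=C/c2nc3cc(F)ccc3n2Cc2ccccc2F)SC1=S` reaches only a limit of this assay, > 50000 nM.

Compound 1 and compound 2 differ in more than one place; the difference between the two cores is not broken down here. Of the two numbers, compound 2 gives the higher one, beyond the scatter from compound 1.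

Going by the values given here, the one change traced twice is 2-fluorophenyl in place of 4-methylphenyl on a saturated chain carbon bound to an aromatic nitrogen. Made on compound 1 it gives an at least 21-fold higher number from compound 1 to compound 3 (1.32 log units; beyond the scatter), the end point of which sits at the limit of > 50000 nM in this assay, at which 1 of the 3 values shown sits.

Compound 4 `O=C1NC(=S)S/C1=C\c1nc2ccccc2n1Cc1ccccc1F` is not yet measured. It arises from compound 2 by 2-fluorophenyl in place of 4-methylphenyl on a saturated chain carbon bound to an aromatic nitrogen, the same change at the same place. The step is expected to read a 5.9-fold higher number from compound 2 to compound 4 (0.77 log units; beyond the scatter), because the same change gave an at least 21-fold higher number from compound 1 to compound 3 (1.32 log units; beyond the scatter). Starting from compound 2, such a step is expected to carry the number past (the limit of > 50000 nM in this assay, at which 1 of the 3 values shown sits), so most likely only a limit would be reported. Compound 4 is estimated at 150000 nM, between 30000 nM and 1000000 nM.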

Compound 4, half-maximal inhibitory concentration: 36100 nM
The estimate for compound 4 lay 4.2-fold (0.62 log units) above the measured number, and the stated range covers the measured number.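

In this assay, the 4-methylbenzyl to 2-fluorobenzyl swap gives a 1.4-fold higher number from compound 2 to compound 4 (0.15 log units; within the scatter), so the large step on the core of compound 1 does not carry over at the same size to the core of compound 2: the same change on two cores in this assay, an at least 21-fold higher number (1.32 log units; beyond the scatter) from compound 1 to compound 3 and a 1.4-fold higher number (0.15 log units; within the scatter) from compound 2 to compound 4, at least 14-fold (1.16 log units) apart, beyond the scatter of two such steps

Compound 3 stands at > 50000 nM, which is a limit of the assay and not a number.

The two cores differ in more than one place, so these two steps show that the size of this change depends on the core here, but not which difference between the cores matters, and two pairs are too few to give a rule for the series.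

Still open, going by these compounds, is whether the carboxylic acid chain or the ring fluorine of the core of compound 1 goes with the large step, and whether an amine in place of the carboxylic acid would give the same result. Also open, on these data alone, is how an unsubstituted benzyl would read on either core, which would separate losing the 4-methyl group from gaining the 2-fluoro group.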